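Chloro to Fluoro Across Two Cores That Show Only Limits

A few compounds are considered here, and "the series" means these few. Any claim that something is new, unique, unknown or untested is made for them only; others in the source may bear on it.

Compound 1, `Clc1ccc(-c2n[nH]cc2N2CCCNCC2)cc1`, in an assay on isolated protein for binding affinity to 5-hydroxytryptamine receptor 4 (Homo sapiens); a higher number here means a weaker inhibitor, a lower number a stronger inhibitor: > 10000 nM
Compound 2, `Fc1ccc(-c2n[nH]cc2N2CCCNCC2)cc1`, in this assay: > 10000 nM
Compound 3, `Clc1cccc(-c2n[nH]cc2N2CCNCC2)c1`, in this assay: > 10000 nM

The three measured compounds all sit at a limit of this assay rather than at a number. For compound 1 the value > 10000 nM is such a limit. For compound 2 the value > 10000 nM is likewise a limit. For compound 3 the value > 10000 nM is a limit as well, so the limit of > 10000 nM in this assay, at which 3 of the 3 values shown sit, describes every measured value shown here.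

Compound 1 and compound 2 differ by fluoro in place of chloro on an aromatic carbon. The step that the two limits leave unreadable from compound 1 to compound 2 cannot be read in size because the limit of > 10000 nM in this assay, at which 3 of the 3 values shown sit, holds for both ends of it.

Compound 3 shares its change with compound 4, `Fc1cccc(-c2n[nH]cc2N2CCNCC2)c1`, which differs from it by fluoro in place of chloro on an aromatic carbon. For the measured compounds named here, this is the same kind of change as the one from compound 1 to compound 2, but the place is not identical: in compound 1 the halogen sits para to a large group, whereas in compound 3 it sits meta to a large group. How the core of compound 1 and the core of compound 3 differ is not broken down here.

Compound 4 has not yet been measured in this assay. Since compound 3 gives only the limit > 10000 nM, and the matching step that the two limits leave unreadable from compound 1 to compound 2 is unreadable, the expected step that the limit leaves unreadable from compound 3 to compound 4 is itself an expectation resting on limits alone. For compound 4 the estimate is 15000 nM, with a range from 4000 nM to 60000 nM, and the result is most likely to be reported again only as a limit.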

Compound 4, inhibition constant: > 10000 nM
Compound 4: only a limit was reported (the forecaster's own chance of this, stated with the estimate: 85%); the middle value does not contradict the limit.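

In this assay compound 4 gives > 10000 nM, which is a limit and not a number. No new step can be read, as the change from compound 3 to compound 4 has a limit at both ends, just as every compound shown does: the limit of > 10000 nM in this assay, at which 4 of the 4 values shown sit.

The compounds shown leave open whether fluoro in place of chloro on an aromatic carbon alters the value in this assay on either core.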